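The compounds below may be only part of what the source reports. "The series", "measured", "known", "first", "only" and "open" are said of these compounds alone.

Measured so far, all in a functional assay on HeLa cells (Homo sapiens) for cytotoxicity, read by MTT assay, with a stated time of 24 h; on this read-out higher numbers stand for weaker inhibition and lower numbers for stronger inhibition:

Compound 1, `CCCCCCCCCCCC(=O)Nc1nnc(S[C@@H]2O[C@H](COC(C)=O)[C@H](OC(C)=O)[C@H](OC(C)=O)[C@H]2OC(C)=O)s1`, gives 51900 nM.
Compound 2, `CCCCCCCCCCCCCC(=O)Nc1nnc(S[C@@H]2O[C@H](COC(C)=O)[C@H](OC(C)=O)[C@H](OC(C)=O)[C@H]2OC(C)=O)s1`, gives 61300 nM.
Compound 3, `CCCCCCCCCCCCCCCC(=O)Nc1nnc(S[C@@H]2O[C@H](CO)[C@H](O)[C@H](O)[C@H]2O)s1`, gives 14200 nM.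

Compound 1 and compound 2 share one core, and the step between them is hydrogen in place of ethyl on a saturated chain carbon, ten or more bonds along the chain from a carbonyl carbon, which in this assay gave a 1.2-fold lower number from compound 2 to compound 1 (0.07 log units; within the scatter). Compound 3 carries a different core; the difference between the two cores is not broken down here. Compound 3 has the lowest number of the three, and its gaps to compound 1 and to compound 2 lie beyond the scatter.

Compound 4, `CCCCCCCCCCCCCC(=O)Nc1nnc(S[C@@H]2O[C@H](CO)[C@H](O)[C@H](O)[C@H]2O)s1`, has not been measured. It stands to compound 3 as compound 1 stands to compound 2: the change is hydrogen in place of ethyl on a saturated chain carbon, ten or more bonds along the chain from a carbonyl carbon, at the same place. Since the same change from compound 2 to compound 1 moved the number only within the scatter, the expected step from compound 3 to compound 4 in this assay is likewise small, a 1.1-fold lower number from compound 3 to compound 4 (0.06 log units; within the scatter). Compound 4 is therefore expected to give about 12500 nM, estimated to fall between 5000 nM and 32000 nM.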

Compound 4, half-maximal inhibitory concentration: 31000 nM
Compound 4: middle estimate off by 2.5-fold (0.39 log units), on the low side, and the stated range covers the measured number.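

In this assay, putting hydrogen in place of ethyl on a saturated chain carbon, ten or more bonds along the chain from a carbonyl carbon, gave a 2.2-fold higher number from compound 3 to compound 4 (0.34 log units; beyond the scatter) on the core of compound 3. Set beside the same change on the other core, the two steps cannot be told apart: the same change on two cores in this assay, a 1.2-fold lower number (0.07 log units; within the scatter) from compound 2 to compound 1 and a 2.2-fold higher number (0.34 log units; beyond the scatter) from compound 3 to compound 4, 2.6-fold (0.41 log units) apart, within the scatter of two such steps.
Going by these compounds alone, this gives no firm sign that the core alters the effect of the change, although only the step on the core of compound 3 lies beyond the scatter, and two pairs of compounds cannot prove that the effect carries over intact from one core to another.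

The compounds shown leave open how the number would move with a longer chain on either core. They also leave open whether a chain ending in an amine or a carboxylic acid would follow the plain chains seen here.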